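Amide nitrogen substituents and lipophilicity, toward compound 4

The source may report more compounds than this note shows. Statements on the series, on what has been measured and on what is new or still open speak of the compounds shown alone.

Measured in a physicochemical assay for lipophilicity, at pH 7.4; a lower number here means a more polar compound, a higher number a more lipophilic compound:
compound 1 `CNC(=O)c1cc(C(=O)NC2CCC2)cn(Cc2ccccc2)c1=O` gives 3.8
compound 2 `CNC(=O)c1cc(C(=O)NC2CCOCC2)cn(Cc2ccccc2)c1=O` gives 2.8
compound 3 `CCNC(=O)c1cc(C(=O)NC)c(=O)n(Cc2ccccc2)c1` gives 3

Of the three numbers, compound 3 holds the second highest. The step of a number 0.20 log units higher from compound 2 to compound 3 (within the scatter) is within the scatter, so compound 2 and compound 3 cannot be ordered against each other; the step of a number 0.80 log units lower from compound 1 to compound 3 (beyond the scatter) is beyond the scatter, so compound 1 is clearly the higher of that pair.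

Compound 4 `CNC(=O)c1cc(C(=O)NCCC(C)C)cn(Cc2ccccc2)c1=O` is not yet measured in this assay. It differs from compound 3 in one place: isopropyl in place of hydrogen on a saturated chain carbon, two bonds along the chain from an amide-type nitrogen. Read one bond further out, the change is ethyl to isopentyl on the amide-type nitrogen.

For the measured compounds named here, only one measured step exchanges one hydrocarbon group for another on that nitrogen: a number 0.80 log units lower from compound 1 to compound 3 (beyond the scatter), where removing two ring carbons lowered the number modestly. The step of a number 1.00 log units lower from compound 1 to compound 2 (beyond the scatter) swaps cyclobutyl for oxan-4-yl and is less comparable. Going from compound 3 to compound 4 enters three carbons and no ring, so a rise at least of the size seen in the cyclobutyl-to-ethyl step is expected, beyond the scatter: a number 1.10 log units higher from compound 3 to compound 4 (beyond the scatter).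

For compound 4 the estimated value is 4.1, with an expected range from 3.6 to 4.6.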

Compound 4, distribution coefficient: 4.8
The estimate for compound 4 lay 0.70 log units below the measured number, and the stated range ends below it.
By their numbers in this assay, from the lowest: compounds 2 and 3 (each within the scatter of the next); then compound 1; then compound 4.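

In this assay compound 4, with isopentyl on the amide-type nitrogen, gives 4.8 and stands clearly above all three earlier compounds, with a number 1.80 log units higher from compound 3 to compound 4 (beyond the scatter) and with a number 2.00 log units higher from compound 2 to compound 4 (beyond the scatter) and also with a number 1.00 log units higher from compound 1 to compound 4 (beyond the scatter) as the steps, each printed as beyond the scatter. A ring is therefore not needed for a high number at this nitrogen: the entering isopropyl carries no ring and no hydrogen-bond donors or acceptors, yet the open-chain isopentyl compound lies above the cyclobutyl compound, and among the three hydrocarbon groups the order runs ethyl, cyclobutyl, isopentyl, with oxan-4-yl in compound 2 not separable from ethyl in compound 3. Nothing shown gives a reason for the size of this step.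

Unbranched pentyl on the same nitrogen would separate the effect of the branch from that of chain length, and a longer chain such as hexyl would show whether the number goes on rising. From the compounds shown here alone, an amine or a carboxylic acid at the end of the chain, in place of the isopropyl, remains open as well, as does any read-out other than this one.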